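Methyl on the Ring Amine Nitrogen: the Same Change Twice

The source may hold more compounds than are shown below. What is called first, only, known or untested is meant among the compounds shown, and "the series" means these compounds.

Compound 1 `CCn1cc(-c2nc3ccccc3[nH]2)c(=O)c2cc(F)c(N3CCNCC3)cc21` gives 10500 nM in a functional assay on KB cells (Homo sapiens) for cytotoxicity, read by MTT assay, with a stated time of 48 h; on this read-out higher numbers stand for weaker inhibition and lower numbers for stronger inhibition.
Compound 2 `CCn1cc(-c2nc3ccccc3[nH]2)c(=O)c2cc(F)c(N3CCN(C)CC3)cc21` gives 36700 nM in this assay.
Compound 3 `CCn1cc(-c2nc3ccc([N+](=O)[O-])cc3s2)c(=O)c2cc(F)c(N3CCNCC3)cc21` gives 700 nM in this assay.

Compound 1 and compound 2 share one core and differ in one place only: methyl in place of hydrogen on an amine nitrogen in a ring. That change gives a 3.5-fold higher number from compound 1 to compound 2 (0.54 log units; beyond the scatter). Compound 3 has a different core; the difference between the two cores is not broken down here, and its number stands well apart from the other two, the nearest being compound 1.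

Compound 4 `CCn1cc(-c2nc3ccc([N+](=O)[O-])cc3s2)c(=O)c2cc(F)c(N3CCN(C)CC3)cc21` has not yet been measured. It stands to compound 3 as compound 2 stands to compound 1: methyl in place of hydrogen on an amine nitrogen in a ring. The place of the change reads the same in both pairs, so this is the same change made a second time on another core.

Beside the measured step from compound 1 to compound 2, the expected step is a 3.6-fold higher number from compound 3 to compound 4 (0.55 log units; beyond the scatter), because the only guide is a 3.5-fold higher number from compound 1 to compound 2 (0.54 log units; beyond the scatter). Going by these compounds, whether the second core carries the change in the same way is unknown, so the range is kept wide. Compound 4 is therefore estimated at 2500 nM, expected to lie between 1000 nM and 7000 nM.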

Compound 4, half-maximal inhibitory concentration: 5800 nM
Estimate against measurement, compound 4: 2.3-fold (0.37 log units) below; the range from low to high includes it.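

On the second core, the change from piperazin-1-yl to 4-methylpiperazin-1-yl gives an 8.3-fold higher number from compound 3 to compound 4 (0.92 log units; beyond the scatter) in this assay, so the methyl step runs in the same direction on both cores. Set side by side, the two steps cannot be told apart in size: the same change on two cores in this assay, a 3.5-fold higher number (0.54 log units; beyond the scatter) from compound 1 to compound 2 and an 8.3-fold higher number (0.92 log units; beyond the scatter) from compound 3 to compound 4, 2.4-fold (0.37 log units) apart, within the scatter of two such steps. This shows that, for these two pairs, the change carried over from one core to the other in direction and in a size that the scatter does not separate, but two pairs do not show that it would hold on any further core, and they give no reason for the step.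

The compounds shown leave open whether an ethyl group, a longer chain or an acetyl group on the same ring nitrogen would follow the methyl step. Within the data shown here, they also leave open how the parts of the difference between the two cores each contribute, since no pair here changes only one of those parts.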